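Replacing methylsulfonyl with fluoro on compound 1

The source may hold more compounds than are shown below. What is called first, only, known or untested is meant among the compounds shown, and "the series" means these compounds.

Among the compounds with values here, in a functional assay on MCF7 cells (Homo sapiens) for antiproliferative activity, read by CellTiter-Glo, with a stated time of 5 days (on this read-out higher numbers stand for weaker inhibition and lower numbers for stronger inhibition), compound 1 (`CC1=C(c2cccc(S(C)(=O)=O)c2)C(c2ccc(OC[C@H](C)N3CC[C@@H](C)C3)cc2)Oc2ccc(O)cc21`) gives 4.3 nM and holds the higher of the two numbers measured so far. Compound 2 (`CC1=C(c2cccc(O)c2)C(c2ccc(OC[C@@H](C)N3CC[C@@H](C)C3)cc2)Oc2ccc(O)cc21`) gives 0.2 nM and the gap between them lies beyond the usual scatter. The next molecule is compound 3 (`CC1=C(c2cccc(F)c2)C(c2ccc(OC[C@H](C)N3CC[C@@H](C)C3)cc2)Oc2ccc(O)cc21`), which keeps the rest of compound 1 but carries fluoro in place of methylsulfonyl on an aromatic carbon. Within the data shown here, no measured pair yet differs in one place only, so any forecast here is loose. Compound 2 at 0.2 nM shows that much lower numbers occur among these molecules. The step expected is a 2.9-fold lower number from compound 1 to compound 3 (0.46 log units; beyond the scatter) toward stronger inhibition, a modest move that may only just clear the scatter. For compound 3 the estimate is 1.5 nM with an expected range from 0.4 nM to 6 nM as its likely span.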

Compound 3, half-maximal inhibitory concentration: 1 nM
Compound 3: the middle estimate sits 1.5-fold (0.18 log units) above what was measured, and the stated range covers the measured number.
By their numbers in this assay, from the lowest: compound 2; then compound 3; then compound 1.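

Within the data shown here, this is the first pair that differs in one place only, so the effect of a single change can be read directly: in this assay putting fluoro in place of methylsulfonyl on the aromatic carbon gives a 4.3-fold lower number from compound 1 to compound 3 (0.63 log units; beyond the scatter) toward stronger inhibition. This position therefore does not depend on methylsulfonyl, since a single fluorine atom replaces its four heavy atoms and its two hydrogen-bond acceptors and the compound still inhibits more strongly. No available evidence says why the number falls.

Compound 2 differs from compound 3 in more than one place, so the effect of its hydroxy group at this position cannot be read as a step. From the compounds shown here alone, how a chloro group, a nitrile or an amine would compare with fluoro at this same position remains open.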